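The compounds below may be only part of what the source reports. "The series", "measured", "known", "first", "only" and "open" are said of these compounds alone.

Measured so far in a functional assay on cells for antagonist activity at C-X-C chemokine receptor type 4 (Homo sapiens), read by fluorescence and calcium flux, with stated times of 25 min and 90 s; on this read-out higher numbers stand for weaker inhibition and lower numbers for stronger inhibition:
compound 1 `O=S1(=O)CCC(CNCCCCN(C[C@H]2Cc3ccccc3CN2)[C@H]2CCCc3cccnc32)CC1` gives 17 nM
compound 2 `CC1(C)CCC(NCCCCN(C[C@H]2Cc3ccccc3CN2)[C@H]2CCCc3cccnc32)CC1` gives 77.6 nM
compound 3 `CC(C)(CN)CCN(C[C@H]1Cc2ccccc2CN1)[C@H]1CCCc2cccnc21` gives 69 nM

Compound 3 stands second highest of the three numbers in this assay; its nearest neighbour is compound 2, the gap between them lying within the scatter, while compound 1 sits furthest away, with a 4.1-fold higher number from compound 1 to compound 3 (0.61 log units; beyond the scatter). The next compound, compound 4 `CC1(C)CCC(NCC(C)(C)CCN(C[C@H]2Cc3ccccc3CN2)[C@H]2CCCc3cccnc32)CC1`, is not yet measured. It differs from compound 3 by 4,4-dimethylcyclohexyl in place of hydrogen on an amine nitrogen, so that the amino end of the chain becomes a (4,4-dimethylcyclohexyl)amino end.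

Among the compounds with values here, two measured steps bear on this change. Within the data shown here, the group that enters is the one already present in compound 2, where a 4.6-fold higher number from compound 1 to compound 2 (0.66 log units; beyond the scatter). More directly, a 1.1-fold lower number from compound 2 to compound 3 (0.05 log units; within the scatter) compares a chain that carries this same group with the plain amine of compound 3, and that step lies within the scatter. Compound 4 is therefore expected to show no step beyond the scatter in this assay, with a 1.1-fold lower number from compound 3 to compound 4 (0.03 log units; within the scatter). The estimate for compound 4 is 65 nM, in a range from 22 nM to 190 nM.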

Compound 4, half-maximal inhibitory concentration: 541 nM
Beside the measured number, compound 4's estimate is 8.3-fold (0.92 log units) below it; the measured number lies above the stated range.
By their numbers in this assay, from the lowest: compound 1; then compounds 3 and 2 (each within the scatter of the next); then compound 4.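

In this assay, putting 4,4-dimethylcyclohexyl in place of hydrogen on the amine nitrogen of this chain is not a neutral change, with a 7.8-fold higher number from compound 3 to compound 4 (0.89 log units; beyond the scatter). The earlier near-equality of compound 2 and compound 3 therefore did not carry over to this change: compound 2 carries the same group and gives 77.6 nM, whereas compound 4, whose chain differs, gives 541 nM, so among these compounds the outcome for this group differs with the chain that bears it. Nothing available here gives a measured explanation for this difference.

The compounds shown leave open whether a plain cyclohexyl or a simple methyl on this amine nitrogen would give a number closer to that of compound 3 or of compound 4. They also leave open whether (1,1-dioxothian-4-yl)methyl on the chain of compound 4 would restore a number like that of compound 1.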